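From compound 3 to compound 4: adding a methoxy

The source may hold more compounds than are shown below. What is called first, only, known or untested is meant among the compounds shown, and "the series" means these compounds.

In a functional assay on A549 cells (Homo sapiens) for inhibition, read by sulforhodamine B assay (on this read-out lower numbers stand for stronger inhibition of growth and higher numbers for weaker inhibition of growth), compound 1 `c1ccc(-c2ccc(-c3ccc(-c4nc5ccccc5[nH]4)cc3)cc2)cc1` gives 41200 nM, compound 2 `FC(F)(F)c1ccc(-c2ccc(-c3ccc(-c4nc5ccccc5[nH]4)cc3)cc2)cc1` gives 36600 nM and compound 3 `Oc1cccc2[nH]c(-c3ccc(-c4ccc(-c5ccccc5)cc4)cc3)nc12` gives 8320 nM. Compound 3 therefore holds the lowest of the three numbers. Compound 4 `COc1ccc(-c2ccc(-c3ccc(-c4nc5c(O)cccc5[nH]4)cc3)cc2)cc1` has not yet been measured and differs from compound 3 in one place: methoxy in place of hydrogen on an aromatic carbon. Put simply, this is methoxy in place of hydrogen on an aromatic carbon.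

For the measured compounds named here, the closest precedent is a 1.1-fold lower number from compound 1 to compound 2 (0.05 log units; within the scatter), where trifluoromethyl takes the carbon that carries the methoxy in compound 4. That step stayed within the scatter. The other measured step, a 5.0-fold lower number from compound 1 to compound 3 (0.69 log units; beyond the scatter), adds the hydroxy that compound 3 and compound 4 share, so it says little about the new change. Going by the values given here, no methoxy compound has been measured, and one precedent is thin support, so the range stays wide. No change beyond the scatter is expected, and the expected step is a 1.0-fold lower number from compound 3 to compound 4 (0.02 log units; within the scatter). For compound 4 the estimated value is 8000 nM, within an expected range of 3000 nM to 22000 nM.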

Compound 4, concentration for 50% growth inhibition: 7690 nM
Compound 4: the middle estimate sits 1.0-fold (0.02 log units) above what was measured, and the stated range covers the measured number.
By their numbers in this assay, from the lowest: compounds 4 and 3 (each within the scatter of the next); then compounds 2 and 1 (each within the scatter of the next).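

In this assay, phenyl to 4-methoxyphenyl gives a 1.1-fold lower number from compound 3 to compound 4 (0.03 log units; within the scatter), so this carbon takes a methoxy with no shift beyond the scatter, even with the hydroxy of compound 3 in place. Together with a 1.1-fold lower number from compound 1 to compound 2 (0.05 log units; within the scatter), this means that two different groups on this carbon, each tested on its own parent compound, have left the number within the scatter, while the only step beyond it remains the hydroxy change, a 5.0-fold lower number from compound 1 to compound 3 (0.69 log units; beyond the scatter). No measurement offered here explains this result.

On these data alone, whether an amine, a carboxylic acid or a longer chain on this same carbon would also stay within the scatter remains open. It is also unknown whether methoxy would give the same result on compound 1, which lacks the hydroxy.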